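The source may hold more compounds than are shown below. What is called first, only, known or untested is meant among the compounds shown, and "the series" means these compounds.

Measured so far:
compound 1 `CCc1cc(C(C)=O)c(O)cc1OCCCCC#N` — 92%
compound 2 `C=CCc1cc(C(C)=O)c(O)cc1OCCCCC#N` — 92%

In an assay on isolated protein for inhibition of leukotriene B4 receptor 1 (Homo sapiens), tested at 10 uM (a lower number here means less inhibition, a higher number more inhibition at the concentration tested (going by the name of the read-out)), compound 2 gives 92%, and compound 1 gives 92%; the two are level at the digits shown, as the step of no change at the digits printed from compound 1 to compound 2 (within the scatter) confirms. Compound 3 `C=CCc1cc(C(C)=O)c(O)cc1OCCCCCCCCC#N` has not yet been measured in this assay. It differs from compound 2 by 4-cyanobutyl in place of cyano on a saturated chain carbon, four bonds along the chain from an oxygen on an aromatic ring. Within the data shown here, the only measured step, no change at the digits printed from compound 1 to compound 2 (within the scatter), concerns a different position and a different kind of change, so no measured step bears directly on lengthening the chain that carries the nitrile. What the data do show is that the shared core of compounds 1 and 2 gives high inhibition in this assay with the shorter chain, and nothing indicates whether the longer chain keeps or loses it. The expectation for compound 3 is therefore set a little below compound 2, with a wide range, as the step of a number 12 percentage points lower from compound 2 to compound 3 (beyond the scatter). Compound 3 is thus estimated at 80%, between 45% and 97%.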

Compound 3, a percentage reported as inhibition, at one concentration (the size of the read-out at that concentration, not a potency): 86%
Beside the measured number, compound 3's estimate is 6 percentage points below it, within the range that was stated.
By their numbers in this assay, from the lowest: compounds 3, 1 and 2 (each within the scatter of the next).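

In this assay, 4-cyanobutyl in place of cyano on a saturated chain carbon, four bonds along the chain from an oxygen on an aromatic ring, gives a number 6 percentage points lower from compound 2 to compound 3 (within the scatter) and so leaves the read-out within the scatter. Compounds 1 and 2 share the same chain and say nothing about this position; compound 3 shows that it accepts the longer nitrile-bearing chain with high inhibition retained at the concentration tested. No measurement at hand accounts for this result.

On these data alone, whether a carboxylic acid or an amine in place of the terminal nitrile keeps this level remains open, as does the effect of a still longer chain or a shorter one. The read-out comes from a single concentration, so the potency of compounds 2 and 3 remains unresolved.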